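Removing the methyl from compound 1

The source may report more compounds than this note shows. Statements on the series, on what has been measured and on what is new or still open speak of the compounds shown alone.

- compound 1 `Cc1ccc(F)cc1NC(=O)CN1CCN(c2nnc(Cc3ccccc3)c3ccccc23)CC1`: 19200 nM
- compound 2 `O=C(CN1CCN(c2nnc(Cc3ccncc3)c3ccccc23)CC1)Nc1ccc(F)c(Cl)c1`: 4 nM
- compound 3 `O=C(CN1CCN(c2nnc(Cc3ccncc3)c3ccccc23)CC1)Nc1cc(C(F)(F)F)ccc1Cl`: 3.7 nM
- compound 4 `O=C(CN1CCN(c2nnc(Cc3ccccc3)c3ccccc23)CC1)Nc1cccc(F)c1`: not yet measured

In a functional assay on MDA-MB-231 cells (Homo sapiens) for cytotoxicity, read by MTT assay, with a stated time of 72 h (a higher number here means a weaker inhibitor, a lower number a stronger inhibitor), compound 1 has the highest number of the three measured, far beyond the scatter from compound 2 and compound 3, which also differ from it elsewhere. Going to compound 4, 5-fluoro-2-methylphenyl becomes 3-fluorophenyl: hydrogen in place of methyl on an aromatic carbon That is hydrogen in place of methyl on an aromatic carbon, ortho to a large group. Among the measured compounds shown here, the only measured single-place step, a 1.1-fold lower number from compound 2 to compound 3 (0.03 log units; within the scatter), also changes the aryl group on the amide-type nitrogen and stays small. For the measured compounds named here, no measured step covers this exact change, so the range stays wide. A step no larger than the scatter is expected: a 1.6-fold lower number from compound 1 to compound 4 (0.20 log units; within the scatter). Compound 4 is estimated at 12000 nM, with an expected range of 500 nM to 40000 nM.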

Compound 4, half-maximal inhibitory concentration: 3730 nM
Compound 4: middle estimate off by 3.2-fold (0.51 log units), on the high side, and the stated range covers the measured number.
By their numbers in this assay, from the lowest: compounds 3 and 2 (each within the scatter of the next); then compound 4; then compound 1.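

In this assay, among the compounds shown here, hydrogen in place of methyl on an aromatic carbon, ortho to a large group, gives a 5.1-fold lower number from compound 1 to compound 4 (0.71 log units; beyond the scatter) and is the only single-place step here beyond the scatter. The methyl at this position therefore has a modest but readable effect on the number, with its removal moving towards a stronger inhibitor. No measured evidence accounts for this step.

On these data alone, whether a chloro or methoxy group on this carbon would rank with methyl or with hydrogen remains open. Also open, as far as these compounds go, is whether the same step would hold on the core of compound 2.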